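Aryl exchange on the shared core: solubility notes

The source may hold more compounds than are shown below. What is called first, only, known or untested is meant among the compounds shown, and "the series" means these compounds.

Measured so far:
compound 1 `CCOC(=O)c1c(-c2ccc(OC)cc2)[nH]c2cccc(OC)c2c1=O`: > 100000 nM
compound 2 `CCOC(=O)c1c(-c2ccc(C(C)(C)C)cc2)[nH]c2cc(OC)ccc2c1=O`: 2000 nM

Two compounds of the series have been run in a physicochemical assay for solubility, in phosphate buffer, at pH 7.4; a higher number here means a more soluble compound, a lower number a less soluble compound. In this assay compound 1 gives > 100000 nM, which is a limit of the assay and not a number. Compound 1 therefore stands at the limit of > 100000 nM in this assay, at which 1 of the 2 values shown sits, and no number inside the measurable range is known for it. Compound 2 gives 2000 nM in this assay, a number well inside the range. Among the measured compounds shown here, no single-point step connects compound 2 to compound 1, so the pair shows only what the two values themselves show.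

The next compound is compound 3 `CCOC(=O)c1c(-c2cccc([N+](=O)[O-])c2)[nH]c2cccc(OC)c2c1=O`. It differs from compound 1 by 3-nitrophenyl in place of 4-methoxyphenyl on an aromatic carbon. With compound 1 at the limit, any change beyond the scatter can only appear as a lower reading. The step of an at least 3.3-fold lower number from compound 1 to compound 3 (0.52 log units; beyond the scatter) is expected to be a moderate decrease, beyond the scatter, with a fair chance that the result is again reported only as a limit. For compound 3 the expected value in this assay is 30000 nM, within 5000 nM to 150000 nM.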

Compound 3, solubility: 49000 nM
Estimate against measurement, compound 3: 1.6-fold (0.21 log units) below, and the stated range covers the measured number.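

In this assay compound 3 gives 49000 nM, the first reading inside the measurable range for the core of compound 1, and it shows that this aromatic carbon, next to the ring nitrogen and ortho to the ethoxycarbonyl group, can carry 3-nitrophenyl in place of 4-methoxyphenyl with the value still high in the range. The exchange gives an at least 2.0-fold lower number from compound 1 to compound 3 (0.30 log units; that floor lies within the scatter), so the pair does not by itself establish a real loss, and only a larger true gap would make one certain. The size of the step stays unresolved because compound 1 gives only a limit, not a number:  the limit of > 100000 nM in this assay, at which 1 of the 3 values shown sits.

The exchange changes both the substituent and its place on the phenyl ring, so 3-methoxyphenyl or 4-nitrophenyl at this carbon would be needed to tell the two apart. Also open, going by these compounds, is how an unsubstituted phenyl, an aminophenyl or a carboxyphenyl would read here, and compound 2 cannot help, since it differs from compound 1 and compound 3 in more than one place.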